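A few compounds are considered here, and "the series" means these few. Any claim that something is new, unique, unknown or untested is made for them only; others in the source may bear on it.

Compound 2 `O=C1COc2ccc(-c3ccc(O)cc3)cc2N1` is the point of departure. In a functional assay on A-375 cells (Homo sapiens) for antiproliferative activity, read by MTT assay, with a stated time of 72 h (a lower number here means a stronger inhibitor, a higher number a weaker inhibitor), compound 2 gives only a limit of the assay, > 40000 nM, and not a number. Within the data shown here, compound 1 `Cc1ccc(N2C(=O)COc3ccc(-c4cnc5ccccc5c4)cc32)cc1` differs from compound 2 in more than one place, so no single step connects them. In this assay compound 1 likewise reaches only a limit, > 40000 nM. Everything measured so far therefore sits at the edge of what the assay can report, as the limit of > 40000 nM in this assay, at which 2 of the 2 values shown sit, makes plain. Compound 3 `COc1ccc(N2C(=O)COc3ccc(-c4ccc(O)cc4)cc32)cc1` arises from compound 2 by one change: 4-methoxyphenyl in place of hydrogen on an amide-type nitrogen in a ring. Compound 1 also carries an aromatic group on the amide-type nitrogen in a ring, and it stays at the limit. The change is expected to move this assay by nothing beyond the scatter, because the limit of > 40000 nM in this assay, at which 2 of the 2 values shown sit, leaves no measured potency to build on. The expected step of a number no higher from compound 2 to compound 3 (the limit leaves the size open) is essentially flat. Compound 3 is estimated at 40000 nM, within 12000 nM to 130000 nM, with a strong chance that only a limit is reported once more.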

Compound 3, half-maximal inhibitory concentration: > 40000 nM
Compound 3 was reported as a limit (the forecaster's own chance of this, stated with the estimate: 70%); the middle value lies on the limit itself.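

Compound 2 and compound 3 both stop at a limit of the assay, so no step can be read between them. The compounds shown leave open which structure, if any, would give a measured number in this assay: the limit of > 40000 nM in this assay, at which 3 of the 3 values shown sit.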